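Bromo addition to compound 2: working notes

A few compounds are considered here, and "the series" means these few. Any claim that something is new, unique, unknown or untested is made for them only; others in the source may bear on it.

Measured so far in a functional assay on P388 cells (Mus musculus) for cytotoxicity; a higher number here means a weaker inhibitor, a lower number a stronger inhibitor:
- compound 1 `Brc1ccc2c(-c3nc(-c4c[nH]c5ccccc45)c[nH]3)c[nH]c2c1`: 4500 nM
- compound 2 `Brc1ccc2c(-c3c[nH]c(-c4c[nH]c5ccccc45)n3)c[nH]c2c1`: 4500 nM

In this assay, compound 2 gives 4500 nM, level with compound 1 at 4500 nM and within the usual scatter of repeated measurements. These two compounds are the only reference points, and they do not differ from each other in one place alone. Within the data shown here, the series therefore offers no measured single-place step to use as a guide.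

The next compound is compound 3 `Brc1ccc2c(-c3c[nH]c(-c4c[nH]c5cc(Br)ccc45)n3)c[nH]c2c1`, which follows from compound 2 through one change (bromo in place of hydrogen on an aromatic carbon). A bromo takes the place of hydrogen on an aromatic carbon of a six-membered aromatic ring of carbon only, part of a fused or bridged system of two rings.

With so little to go on, only a modest shift is expected, leaning towards a weaker inhibitor, and a result within the scatter would be no surprise. The expected step is a 1.6-fold higher number from compound 2 to compound 3 (0.19 log units; within the scatter), and its direction remains uncertain. The estimate for compound 3 is 7000 nM, with an expected range from 2000 nM to 20000 nM.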

Compound 3, half-maximal inhibitory concentration: 4500 nM
The estimate for compound 3 lay 1.6-fold (0.19 log units) above the measured number; low and high end bracket the measured number.
By their numbers in this assay, from the lowest: compounds 1, 2 and 3 (each within the scatter of the next).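

In this assay, bromo in place of hydrogen on an aromatic carbon gives no change at the digits printed from compound 2 to compound 3 (within the scatter) and, read against the other reference, no change at the digits printed from compound 1 to compound 3 (within the scatter) for the same kind of change. Among these compounds, these are the first measured single-place steps, and they show that, at this place on a six-membered aromatic ring of carbon only, meta to a fused ring and para to a fused ring, an added bromo leaves the read-out within the scatter. No supporting measurement is available to explain this result.

From the compounds shown here alone, it remains open whether this place stays as insensitive with a different kind of group, such as an amine, a carboxylic acid or a longer chain, in place of the bromo. Going by these compounds, it is also open whether the same bromo would leave the read-out unmoved on other carbons of the shared core, so this flat reading applies only to compounds 1, 2 and 3.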